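This account rests on a few compounds, and the source may have more. Where it says the series, first, only, none or still open, it means among the compounds named here.

Compound 1 `O=C(CCCCCCc1ccccc1)c1ncc(C(=O)C(F)(F)F)o1` carries a trifluoromethyl on a carbonyl carbon of the shared core, and in an assay on HEK-293T cells for inhibition of diacylglycerol lipase-alpha (Homo sapiens), read by colorimetric assay (on this read-out lower numbers stand for stronger inhibition and higher numbers for weaker inhibition), compound 1 gives 1820 nM. Compound 2 `CC(=O)c1cnc(C(=O)CCCCCCc2ccccc2)o1` differs from it by methyl in place of trifluoromethyl on that carbonyl carbon. In this assay compound 2 gives > 10000 nM, which is a limit of the assay and not a number. For the measured compounds named here, the step of an at least 5.4-fold higher number from compound 1 to compound 2 (0.73 log units; beyond the scatter) is thus known only as a lower bound, since compound 2 sits at the limit of > 10000 nM in this assay, at which 1 of the 2 values shown sits, and compound 2 stands as the weaker of the two compounds measured so far.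

Compound 3 `CS(=O)(=O)c1cnc(C(=O)CCCCCCc2ccccc2)o1` has not yet been measured. It differs from compound 2 by methylsulfonyl in place of acetyl on an aromatic carbon. Going by the values given here, the only measured step that bears on this position is an at least 5.4-fold higher number from compound 1 to compound 2 (0.73 log units; beyond the scatter), which showed that exchanging the group on this carbon away from trifluoromethyl cost activity beyond the scatter. With compound 2 already at a limit, compound 3 is expected to stay near or beyond that limit, a step that the limit leaves unreadable from compound 2 to compound 3. Compound 3 is therefore estimated at 15000 nM, within a range from 3000 nM to 60000 nM.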

Compound 3, half-maximal inhibitory concentration: > 10000 nM
Compound 3 was reported as a limit; the forecaster's own chance of this, stated with the estimate: 70%; the middle value does not contradict the limit.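

Methylsulfonyl in place of (trifluoromethyl)carbonyl on this aromatic carbon, next to the ring oxygen, brings an at least 5.4-fold higher number from compound 1 to compound 3 (0.73 log units; beyond the scatter), so the loss at this position is no longer tied to acetyl alone: it now appears with a replacement that keeps a carbonyl on the ring and with one that has none. In this assay, among the three compounds shown, only compound 1 gives a measured number, 1820 nM, and this makes the (trifluoromethyl)carbonyl group the only one here that gives a reading inside the range of the assay. Acetyl and methylsulfonyl cannot be ranked against each other, and the step between compound 2 and compound 3 cannot be read, because both compounds end at the same limit: the limit of > 10000 nM in this assay, at which 2 of the 3 values shown sit.

As far as these compounds go, how far compound 2 and compound 3 lie beyond that limit remains open, and so does whether another group on this aromatic carbon, such as a nitrile, a carboxylic acid or an amide, would give a measured number at all. Also open, from the compounds shown here alone, is how a shorter or longer chain on the ring atom that bears the large group would read with each of these groups in place.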